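Chloro Added to an Anilide Core, Growth Inhibition in Lung Cells

A few compounds are considered here, and "the series" means these few. Any claim that something is new, unique, unknown or untested is made for them only; others in the source may bear on it.

Measured so far in a functional assay on NCI-H460 cells (Homo sapiens) for inhibition, read by MTT assay, with a stated time of 24 h, tested at 10 ug/mL; a higher number here means more inhibition of growth at the concentration tested, a lower number less inhibition of growth:
compound 1, `O=C(CCCCC(S)CCS)Nc1ccccc1`, gives 8.37%
compound 2, `O=C(CCCCC(S)CCS)Nc1ccc(Cl)cc1`, gives 22%
compound 3, `CC(=O)SCCC(CCCCC(=O)Nc1ccccc1)SC(C)=O`, gives 14.2%

Compound 1 and compound 2 share a core with two free thiol groups; compound 3 carries both sulfur atoms as thioacetates. The difference between the core of compound 3 and the core of compound 1 is not broken down here. Within the data shown here, the one counted change among the measured compounds is chloro in place of hydrogen on an aromatic carbon; it made the step of a number 13.6 percentage points higher from compound 1 to compound 2 (beyond the scatter). The values of compound 3 and compound 1 lie within the scatter of each other, as do those of compound 3 and compound 2, so no order can be read between them.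

Compound 4, `CC(=O)SCCC(CCCCC(=O)Nc1ccccc1Cl)SC(C)=O`, has not yet been measured. It differs from compound 3 by chloro in place of hydrogen on an aromatic carbon. This is the same kind of change as from compound 1 to compound 2, but not the same: in compound 2 the chloro stands para to a large group, in compound 4 ortho to a large group. Among the measured compounds shown here, only one such step is known, so the expectation rests on a single example on a different core. Compound 4 is expected to give 22% in this assay, with a range from 10% to 36%. That expectation means a step of a number 7.8 percentage points higher from compound 3 to compound 4 (within the scatter), taken somewhat smaller than the measured one because a number 13.6 percentage points higher from compound 1 to compound 2 (beyond the scatter) was made at a different place on a different core.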

Compound 4, percent growth inhibition at one concentration: 11.4%
Estimate against measurement, compound 4: 10.6 percentage points above; low and high end bracket the measured number.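

In this assay, chloro in place of hydrogen on an aromatic carbon of the thioacetate core gave a number 2.8 percentage points lower from compound 3 to compound 4 (within the scatter), so on this core the change made no difference that can be told from the usual variation between repeated measurements. The same kind of change therefore did not carry over as the same result from the free-thiol core to the thioacetate core: the same change on two cores in this assay, a number 13.6 percentage points higher (beyond the scatter) from compound 1 to compound 2 and a number 2.8 percentage points lower (within the scatter) from compound 3 to compound 4, 16.4 percentage points apart, beyond the scatter of two such steps. These two steps alone do not show that the core is what separates them, for they differ in two things at once: the form of the sulfur atoms, and the place of the chloro, which in compound 4 stands ortho to a large group and in compound 2 stands elsewhere on the ring.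

What the compounds shown leave open is which of those two differences matters, a question that a thioacetate compound with the chloro placed as in compound 2, and a free-thiol compound with it placed as in compound 4, could settle. Also open, as far as these compounds go, is how other groups on the same ring, such as a methoxy group, a nitrile or a carboxylic acid, would behave on either core.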